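The compounds below may be only part of what the source reports. "The series", "measured", "known", "first", "only" and "open" are said of these compounds alone.

Measured so far:
compound 1 `O=c1c2ccccc2[se]n1-c1nc(SCc2ccccc2)n[nH]1`: > 50000 nM
compound 2 `CCCCCCSc1n[nH]c(-n2[se]c3ccccc3c2=O)n1`: 39300 nM
compound 3 `Cc1ccc(CSc2n[nH]c(-n3[se]c4ccccc4c3=O)n2)cc1`: > 50000 nM

In an ADME assay on L929 cells (Mus musculus) for antiproliferative activity, read by CCK-8 assay, with a stated time of 48 h (a higher number here means a weaker inhibitor, a lower number a stronger inhibitor), compound 3 gives only a limit of the assay, > 50000 nM, and not a number. Compound 1 likewise gives a limit, > 50000 nM. Compound 2 gives 39300 nM; the step of an at least 1.2-fold lower number from compound 1 to compound 2 (0.10 log units; that floor lies within the scatter) and the step of an at least 1.2-fold higher number from compound 2 to compound 3 (0.10 log units; that floor lies within the scatter) are both floors that lie within the scatter. The step that the two limits leave unreadable from compound 1 to compound 3 cannot be read because of the limit of > 50000 nM in this assay, at which 2 of the 3 values shown sit. Compound 4 `O=c1c2ccccc2[se]n1-c1nc(SCc2ccc(Cl)cc2)n[nH]1` differs from compound 3 by chloro in place of methyl on an aromatic carbon. Within the data shown here, no measured step covers this exchange, and with compound 3 sitting at a limit no size of step can be drawn from its neighbours; the expectation is therefore no step beyond the scatter, a number no higher from compound 3 to compound 4 (the limit leaves the size open). Compound 4 is expected to give about 50000 nM, within 25000 nM to 100000 nM, most likely reported again as a limit.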

Compound 4, half-maximal inhibitory concentration: 39500 nM
Compound 4: middle estimate off by 1.3-fold (0.10 log units), on the high side; the measured number falls inside the stated range.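

In this assay the chloro group at this position gives a readable number where methyl and hydrogen gave only limits, yet both steps are only floors (an at least 1.2-fold lower number from compound 3 to compound 4 (0.10 log units; that floor lies within the scatter); an at least 1.2-fold lower number from compound 1 to compound 4 (0.10 log units; that floor lies within the scatter)). Pentyl and 4-chlorophenyl on the saturated chain carbon bound to a sulfur cannot be told apart (a 1.0-fold higher number from compound 2 to compound 4 (0.00 log units; within the scatter)).

The true size of any step that touches a limit cannot be read: the limit of > 50000 nM in this assay, at which 2 of the 4 values shown sit. From the compounds shown here alone, whether a methoxy group or an amine at this position would move the number beyond the scatter stays open.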